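Trimming Isopropyl to Ethyl on a Soluble Series

The source may hold more compounds than are shown below. What is called first, only, known or untested is meant among the compounds shown, and "the series" means these compounds.

Of the compounds shown here, three sharing one core have been measured so far in a physicochemical assay for solubility, read by nephelometry, measured as kinetic solubility (a higher number here means a more soluble compound, a lower number a less soluble compound), and give close results. Compound 1 `CC[C@H]1CC[C@H](n2c(=O)[nH]c3ncc(NC(C)=O)cc3c2=O)CC1` gives 22000 nM in this test, compound 2 `CC(C)[C@H]1CC[C@H](n2c(=O)[nH]c3ncc(N)cc3c2=O)CC1` gives 25000 nM in this test and compound 3 `CC(C)[C@H]1CC[C@@H](n2c(=O)[nH]c3ncc(N)cc3c2=O)CC1` gives 17000 nM in this test. Repeated measurements of a single compound always scatter somewhat, and the gaps from compound 2 to each of the other two lie within that scatter, so compound 2 holds no distinct rank among them.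

Compound 4 `CC[C@H]1CC[C@H](n2c(=O)[nH]c3ncc(N)cc3c2=O)CC1` departs from compound 2 through hydrogen in place of methyl on a saturated chain carbon bound to a saturated chain carbon and a saturated ring carbon in a swap of hydrogen in place of methyl on a saturated chain carbon bound to a saturated chain carbon and a saturated ring carbon (isopropyl to ethyl). For the measured compounds named here, no measured step makes this swap. Going by the values given here, the only measured step is a 1.5-fold lower number from compound 2 to compound 3 (0.17 log units; within the scatter) and it reflects the fact that compounds 2 and 3 differ only in the configuration as drawn so it offers only loose guidance, showing compound 3 staying close to compound 2. The expected change is no change at the digits printed from compound 2 to compound 4 (within the scatter) and no move beyond the scatter is expected in either direction. Compound 4 is estimated to give 25000 nM and is expected to fall between 12000 nM and 50000 nM.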

Compound 4, solubility: 55000 nM
Compound 4: the middle estimate sits 2.2-fold (0.34 log units) below what was measured; measured number above the stated range.
By their numbers in this assay, from the lowest: compounds 3, 1 and 2 (each within the scatter of the next); then compound 4.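

In this assay, for the compounds shown here, there is a 2.2-fold higher number from compound 2 to compound 4 (0.34 log units; beyond the scatter), a modest move beyond the scatter, so trimming isopropyl to ethyl changes the number in a way that the only earlier step, a 1.5-fold lower number from compound 2 to compound 3 (0.17 log units; within the scatter), did not. The compounds now also show a second single change ending at compound 4, hydrogen in place of acetyl on a nitrogen on an aromatic ring, with a 2.5-fold higher number from compound 1 to compound 4 (0.40 log units; beyond the scatter), again modest and beyond the scatter. Nothing at hand accounts for either of these two steps, so each stands as an observation only.

The compounds shown leave open how a methyl, a propyl or a cyclopropyl group would compare with ethyl and isopropyl at this place on the saturated ring. Going by these compounds alone, they also leave open whether the step from isopropyl to ethyl would look the same in the other ring configuration, the one drawn in compound 3, or with the acetyl group of compound 1 kept on the nitrogen.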